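A Bromo Group Added to the Ester Ring of Compound 3

The source may report more compounds than this note shows. Statements on the series, on what has been measured and on what is new or still open speak of the compounds shown alone.

Three measured compounds share one core and differ in the ring attached through sulfur. In an assay on HEK293 cells for displacement of a labelled ligand from prostaglandin D2 receptor 2 (Homo sapiens) (a higher number here means a weaker inhibitor, a lower number a stronger inhibitor), compound 1 `O=C(O)Cn1c(SCc2cccc(Cl)c2)nc2ccccc21` gives 186 nM. Compound 2 `O=C(O)Cn1c(SCc2ccccc2Br)nc2ccccc21` gives 580 nM, the step being a 3.1-fold higher number from compound 1 to compound 2 (0.49 log units; beyond the scatter). Compound 3 `COC(=O)c1cccc(CSc2nc3ccccc3n2CC(=O)O)c1` gives 450 nM, the step being a 2.4-fold higher number from compound 1 to compound 3 (0.38 log units; beyond the scatter). Compound 3 therefore stands second highest of the three numbers, within the scatter of compound 2 and clearly higher than compound 1.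

Compound 4 `COC(=O)c1cccc(CSc2nc3ccccc3n2CC(=O)O)c1Br` differs from compound 3 by bromo in place of hydrogen on an aromatic carbon. Within the data shown here, no measured step adds a group at that place; both known steps were modest, and the step from compound 1 to compound 2 changes halogen and position together. He therefore expects for compound 4 only a small shift, if any, in this assay, namely a 1.1-fold lower number from compound 3 to compound 4 (0.03 log units; within the scatter). His estimate for compound 4 is 420 nM, ranging from 150 nM to 1200 nM.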

Compound 4, half-maximal inhibitory concentration: 2900 nM
For compound 4 the middle estimate is 6.9-fold (0.84 log units) below the measured one, outside the stated range (above it).
By their numbers in this assay, from the lowest: compound 1; then compounds 3 and 2 (each within the scatter of the next); then compound 4.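

On this aromatic carbon, ortho to a methoxycarbonyl group, bromo in place of hydrogen gives a 6.4-fold higher number from compound 3 to compound 4 (0.81 log units; beyond the scatter) in this assay and thus shows that this position is not indifferent to an added atom. Read from the other side, methoxycarbonyl in place of hydrogen gives a 5.0-fold higher number from compound 2 to compound 4 (0.70 log units; beyond the scatter) and so the two groups together stand clearly above either one alone. Nothing measured here explains this rise. As far as these compounds go, whether a fluoro or methyl group at this carbon, or a carboxylic acid in place of the methoxycarbonyl group, would raise the number as well remains open.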